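The compounds below may be only part of what the source reports. "The series", "measured", "known", "first", "only" and "open" are said of these compounds alone.

Measured so far:
compound 1 `CCOc1cc(C)c(-c2cccc(COc3ccc(S(=O)(=O)CC(=O)O)cc3)c2)c(C)c1` with 63.1 nM
compound 2 `Cc1cc(OCCCS(C)(=O)=O)cc(C)c1-c1cccc(COc2ccc(S(=O)(=O)CC(=O)O)cc2)c1` with 170 nM
compound 3 `O=C(O)CS(=O)(=O)c1ccc(OCc2cccc(-c3ccccc3F)c2)cc1` with 257 nM

All three were tested in a functional assay on CHO cells for agonist activity at Free fatty acid receptor 1 (Homo sapiens), read by FLIPR and calcium flux; a higher number here means that more compound is needed for the effect, a lower number that less compound is needed. Compound 3 has the highest number of the three. Its nearest neighbour is compound 2, and the two lie within the scatter of each other, so no order between them can be claimed; against compound 1 the gap is beyond the scatter, so compound 1 needs clearly less compound than compound 3.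

Compound 4 `Cc1ccc(-c2cccc(COc3ccc(S(=O)(=O)CC(=O)O)cc3)c2)c(Cl)c1` is not yet measured. It differs from compound 3 in one place: 2-chloro-4-methylphenyl in place of 2-fluorophenyl on an aromatic carbon.

Within the data shown here, the only step measured between neighbours, a 2.7-fold higher number from compound 1 to compound 2 (0.43 log units; beyond the scatter), changes a different part of the molecule, so it does not bear directly on this change. What the numbers do show is that compound 1 and compound 2, which carry substituted phenyls, both give lower numbers than compound 3 with its 2-fluorophenyl, though only the gap to compound 1 is beyond the scatter.

On that basis compound 4 is expected to give a somewhat lower number than compound 3, a step of about a 2.3-fold lower number from compound 3 to compound 4 (0.37 log units; beyond the scatter), and its estimated value is 110 nM, with a likely range from 40 nM to 320 nM.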

Compound 4, half-maximal effective concentration: 36.3 nM
Compound 4: middle estimate off by 3.0-fold (0.48 log units), on the high side; the whole stated range lies above it.
By their numbers in this assay, from the lowest: compounds 4 and 1 (each within the scatter of the next); then compounds 2 and 3 (each within the scatter of the next).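

In this assay, among these compounds, putting 2-chloro-4-methylphenyl in place of 2-fluorophenyl on an aromatic carbon, meta to a large group, gives a 7.1-fold lower number from compound 3 to compound 4 (0.85 log units; beyond the scatter) and is the first measured step at this position; it shows that the number responds clearly to what this ring carries, even though the group entering has only one more heavy atom than the group leaving, 8 against 7. The change also brings compound 3's close relative into the range of the lowest number seen before, for compound 4 now lies within the scatter of compound 1 at 63.1 nM and so no order between those two can be claimed. Nothing measured here explains why the swap lowers the number, and the step is a single observation that supports no wider rule for this position.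

Going by these compounds, the swap changes two things at once, fluorine to chlorine and the addition of a methyl, so the share of the step that belongs to each stays open. Also open, on these data alone, is how this ring would respond to other groups, such as a nitrile or an amine, in place of the chlorine or the methyl.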